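Amide aryl swap on the shared core: toxicity notes

The source may report more compounds than this note shows. Statements on the series, on what has been measured and on what is new or still open speak of the compounds shown alone.

Compound 1 `COc1ccc(-c2cnc(NC(=O)c3ccco3)n2C)cc1`: in a toxicity assay on THP-1 cells (Homo sapiens) for inhibition (on this read-out lower numbers stand for higher toxicity in this test and higher numbers for lower toxicity in this test), compound 1 gives > 100000 nM, a limit of the assay.
Compound 2 `COc1ccc(-c2cnc(NC(=O)c3ccccc3C)n2C)cc1`: in this assay compound 2 gives > 100000 nM, likewise a limit.

Compound 2 stands at the limit, where both values recorded sit (the limit of > 100000 nM in this assay, at which 2 of the 2 values shown sit). The step that the two limits leave unreadable from compound 1 to compound 2 is accordingly unreadable. Compound 3 `COc1ccc(-c2cnc(NC(=O)c3cccc(Br)c3)n2C)cc1` differs from compound 2 by 3-bromophenyl in place of 2-methylphenyl on a carbonyl carbon. Among the compounds with values here, no measured step bears readably on this change, so no shift beyond the scatter is expected in this assay. Compound 3 is expected at 100000 nM (30000 nM to 300000 nM). The expected step for compound 3 is a number no higher from compound 2 to compound 3 (the limit leaves the size open), and a limit is again the likely report.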

Compound 3, half-maximal cytotoxic concentration: > 100000 nM
Compound 3: a limit, no number (the forecaster's own chance of this, stated with the estimate: 80%); the middle value sits exactly at the limit.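

No step among compound 1, compound 2 and compound 3 can be read in this assay, as all three values are limits: the limit of > 100000 nM in this assay, at which 3 of the 3 values shown sit.

The compounds shown leave open whether furan-2-yl, 2-methylphenyl and 3-bromophenyl differ at all on this read-out.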